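Replacing a Sulfonyl Hydrazide with a Nitrile

This account rests on a few compounds, and the source may have more. Where it says the series, first, only, none or still open, it means among the compounds named here.

Compound 1 `CCCCS(=O)(=O)NNC(=O)[C@@H](NC(=O)c1cccc(Cn2ccnc2)c1)[C@@H](C)CC` was put through an assay on HEK293 cells for displacement of a labelled ligand from Type-2 angiotensin II receptor (Homo sapiens), tested at 1 uM (on this read-out higher numbers stand for a stronger effect at the one concentration tested and lower numbers for a weaker effect), but its outcome is recorded only as "not determined" (no result reported), so no number places it. Two close relatives of compound 1 were measured: compound 2 `CC[C@H](C)[C@H](NC(=O)c1cccc(Cn2ccnc2)c1)C(=O)NNS(=O)(=O)c1ccccc1` gives 6% in this assay, and compound 3 `CC[C@H](C)[C@H](NC(=O)c1cccc(Cn2ccnc2)c1)C(=O)NNS(=O)(=O)c1ccc(C)cc1` gives 4%. Within the data shown here, the single measured step, a number 2 percentage points lower from compound 2 to compound 3 (within the scatter), comes from a methyl in place of hydrogen on an aromatic carbon. Compound 4 `CC[C@H](C)[C@H](NC(=O)c1cccc(Cn2ccnc2)c1)C(=O)NC#N` differs from compound 1 by cyano in place of (butylsulfonyl)amino on an amide-type nitrogen. Among the measured compounds shown here, no measured step mirrors this change, so the expectation can rest only on compounds 2 and 3, which both show weak effects at the tested concentration. Compound 4 is therefore expected to give about 5% in this assay, with a likely range from -5% to 15%.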

Compound 4, a percentage reported as inhibition, at one concentration (the size of the read-out at that concentration, not a potency): 6%
Compound 4: middle estimate off by 1 percentage points, on the low side, and the stated range covers the measured number.
By their numbers in this assay, from the lowest: compounds 3, 2 and 4 (each within the scatter of the next).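

Swapping the whole sulfonyl-bearing group for the much smaller cyano on the amide-type nitrogen leaves the effect in this assay as weak as before: the read-out gives a number 2 percentage points higher from compound 3 to compound 4 (within the scatter) and no change at the digits printed from compound 2 to compound 4 (within the scatter) in this swap. At this one concentration, then, compounds with and without the sulfonyl group cannot be told apart. No supporting data bear on why this is so. Still open, from the compounds shown here alone, is whether a hydroxyl group, an amine or a longer chain on the amide-type nitrogen would give a stronger read-out.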